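The compounds below may be only part of what the source reports. "The series", "measured", "known", "first", "only" and "open" are said of these compounds alone.

Compound 1, `Nc1nc(NCCNc2ncc(-c3ncc[nH]3)c(-c3ccc(F)cc3Cl)n2)ccc1[N+](=O)[O-]`, in an ADME assay on microsomes from liver (Canis lupus familiaris) for metabolic stability; a higher number here means that the compound lasts longer, a lower number that the compound disappears faster: > 0.5 h, a limit of the assay.
Compound 2, `Nc1nc(NCCNc2ncc(-c3ncc[nH]3)c(-c3ccc(F)cc3Br)n2)ccc1[N+](=O)[O-]`, in this assay: > 0.5 h, also a limit of the assay.

Compound 2 therefore stands at the limit of > 0.5 h in this assay, at which 2 of the 2 values shown sit, without a number of its own. Going by the values given here, the only measured step, a step that the two limits leave unreadable from compound 1 to compound 2, cannot be read because the limit of > 0.5 h in this assay, at which 2 of the 2 values shown sit, caps both ends of it. Compound 3, `Cc1ccc(-c2nc(NCCNc3ccc([N+](=O)[O-])c(N)n3)ncc2-c2ncc[nH]2)c(Br)c1`, differs from compound 2 by methyl in place of fluoro on an aromatic carbon. Among the compounds with values here, no measured step speaks to a methyl for a fluoro, so the expected step that the limit leaves unreadable from compound 2 to compound 3 rests on compound 2 alone and is expected to stay within the scatter. Compound 3 is estimated at 1 h, between 0.5 h and 3 h, most likely reported again only as a limit.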

Compound 3, half-life: > 0.5 h
Compound 3 was reported as a limit; the forecaster's own chance of this, stated with the estimate: 70%; the middle value lies beyond the limit too.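

Compound 3 also sits at a limit of this assay, so its steps from compound 1 and from compound 2 cannot be read: the limit of > 0.5 h in this assay, at which 3 of the 3 values shown sit.

How long each of these compounds actually lasts, and whether the swapped groups make any difference to that, stays open.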